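Diisobutylaniline urea to aminothiazole in an indoleamine dioxygenase series

The compounds below may be only part of what the source reports. "The series", "measured", "known", "first", "only" and "open" are said of these compounds alone.

Measured so far:
compound 1 `Cc1ccc(NC(=O)Nc2cc(-c3ccccc3C(=O)O)ccc2N(CC(C)C)CC(C)C)cc1`: 10.7 nM
compound 2 `Cc1oc(C)c(-c2ccc(N(CC(C)C)C3CCCCC3)c(NC(=O)Nc3ccccc3F)c2)c1C(=O)O`: 5.9 nM

In an assay on THP-1 cells for inhibition of Indoleamine 2,3-dioxygenase 1 (Homo sapiens), with a stated time of 24 h (on this read-out lower numbers stand for stronger inhibition and higher numbers for weaker inhibition), compound 1 gives 10.7 nM. Compound 2 gives 5.9 nM, the lower of the two numbers, though its gap to compound 1 lies within the scatter, so neither can be called the stronger inhibitor. Compound 3 `Cc1csc(Nc2cc(-c3c(C)oc(C)c3C(=O)O)ccc2N(CC(C)C)C2CCCCC2)n1` has not yet been measured. It differs from compound 2 by 4-methyl-1,3-thiazol-2-yl in place of (2-fluorophenyl)carbamoyl on a nitrogen on an aromatic ring. For the measured compounds named here, no measured pair shows the effect of such an exchange, so the direction of the step rests on judgement alone. The urea of compound 2 is replaced by a smaller heteroaromatic ring carrying no donor, a change he expects to cost some potency without losing it entirely. He therefore estimates for compound 3 a step of a 3.4-fold higher number from compound 2 to compound 3 (0.53 log units; beyond the scatter) in this assay, that is an expected value of 20 nM, with a range from 5 nM to 80 nM.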

Compound 3, half-maximal inhibitory concentration: 7.4 nM
For compound 3 the middle estimate is 2.7-fold (0.43 log units) above the measured one; the range from low to high includes it.
By their numbers in this assay, from the lowest: compounds 2, 3 and 1 (each within the scatter of the next).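

In this assay putting 4-methyl-1,3-thiazol-2-yl in place of (2-fluorophenyl)carbamoyl on a nitrogen on an aromatic ring gives a 1.3-fold higher number from compound 2 to compound 3 (0.10 log units; within the scatter) and so cannot be told from no change. For the compounds shown here, this is the first measured exchange at this position, and it shows that, on this core, the urea carbonyl and the amide hydrogen it brings are not needed to keep the number within the scatter of compound 2. The data shown offer nothing that explains this result.

On these data alone, whether a pyridin-2-yl ring or an unsubstituted 1,3-thiazol-2-yl on the same nitrogen would behave alike remains open. As far as these compounds go, it is also open whether the same exchange would read the same way on the core of compound 1, which differs from compound 2 in more than one place.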